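Compound 4 and a Series Held at Its Limit

This account rests on a few compounds, and the source may have more. Where it says the series, first, only, none or still open, it means among the compounds named here.

In a functional assay on ECa-109 cells (Homo sapiens) for cytotoxicity, read by MTT assay, with a stated time of 48 h (a higher number here means a weaker inhibitor, a lower number a stronger inhibitor), compound 1 `COc1ccc(-c2c[nH]c(=O)n2-c2cc(OC)c(OC)c(OC)c2)cc1` gives > 50000 nM, which is a limit and not a number. Compound 2 `COc1cc(NC(=O)n2cc(-c3ccc(O)cc3)n(-c3cc(OC)c(OC)c(OC)c3)c2=O)cc(OC)c1OC` also reaches only a limit, > 50000 nM. Compound 3 `COc1ccc(-c2cn(C(=O)Nc3cc(OC)c(OC)c(OC)c3)c(=O)n2-c2cc(OC)c(OC)c(OC)c2)cc1OC` likewise gives only a limit, > 50000 nM. Among the compounds with values here, compound 3 therefore stands with the other two, and the series so far rests on (the limit of > 50000 nM in this assay, at which 3 of the 3 values shown sit).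

Compound 4 `COc1ccc(-c2cn(C(=O)Nc3cc(OC)c(OC)c(OC)c3)c(=O)n2-c2cc(OC)c(OC)c(OC)c2)cc1O` departs from compound 3 in one place: hydrogen in place of methyl on an oxygen on an aromatic ring. In words, hydrogen replaces methyl on an oxygen on an aromatic ring, so that 3,4-dimethoxyphenyl becomes 3-hydroxy-4-methoxyphenyl.

Within the data shown here, only one measured step bears on this change, a step that the two limits leave unreadable from compound 2 to compound 3. It also alters that same aromatic group, but it has no readable size, so it offers no magnitude to carry over. Among the measured compounds shown here, no measured compound carries the 3-hydroxy-4-methoxyphenyl group. In this assay, the most likely outcome is therefore that compound 4 stays at the limit, with a modest move towards a stronger inhibitor as the only readable alternative. The expected step of an at least 1.2-fold lower number from compound 3 to compound 4 (0.09 log units; that floor lies within the scatter) is an estimate with little behind it. For compound 4, the estimated value is 40000 nM, with an expected range from 8000 nM to 50000 nM.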

Compound 4, half-maximal inhibitory concentration: > 50000 nM
Compound 4 was reported as a limit (the forecaster's own chance of this, stated with the estimate: 60%); middle value at least 1.2-fold (0.09 log units) from the limit.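

In this assay compound 4 gives > 50000 nM, which is a limit and not a number. The steps to compound 4 from compound 3 and from compound 2 therefore cannot be read, and the series stays where it was: the limit of > 50000 nM in this assay, at which 4 of the 4 values shown sit.

The compounds shown leave open what change to the shared core, if any, would give a measurable value in this assay.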